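Lengthening the Ester Chain of Compound 2

The source may hold more compounds than are shown below. What is called first, only, known or untested is meant among the compounds shown, and "the series" means these compounds.

In a functional assay on A549 cells (Homo sapiens) for cytotoxicity, read by MTT assay, with a stated time of 24 h, tested at 40 uM (a higher number here means a weaker effect of the compound at the concentration tested, a lower number a stronger effect), compound 2 `CCCCCCCCCCCCCOC(=O)CCC(=O)N1CCN(CCCOc2cc3c(Nc4ccc(F)c(Cl)c4)ncnc3cc2OC)CC1` gives 71.1%, while compound 1 `CCCOC(=O)CCC(=O)N1CCN(CCCOc2cc3c(Nc4ccc(F)c(Cl)c4)ncnc3cc2OC)CC1` gives 80.9%; the two numbers stand together, since a number 9.8 percentage points lower from compound 1 to compound 2 (within the scatter). Compound 3 `CCCCCCCCCCCCCCCOC(=O)CCC(=O)N1CCN(CCCOc2cc3c(Nc4ccc(F)c(Cl)c4)ncnc3cc2OC)CC1` differs from compound 2 by ethyl in place of hydrogen on a saturated chain carbon, ten or more bonds along the chain from an oxygen next to a carbonyl group. Within the data shown here, the only measured step of a related kind, from compound 1 to compound 2, was a far larger lengthening of the same chain and still stayed within the scatter, so no step beyond the scatter is expected in this assay. For compound 3 the expected value is 68%, with a range from 50% to 85%, an expected step of a number 3.1 percentage points lower from compound 2 to compound 3 (within the scatter).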

Compound 3, a percentage reported as activity, at one concentration (the size of the read-out at that concentration, not a potency): 85.5%
Compound 3: the middle estimate sits 17.5 percentage points below what was measured, and the stated range ends below it.
By their numbers in this assay, from the lowest: compounds 2, 1 and 3 (each within the scatter of the next, the first and the last beyond it).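

In this assay adding ethyl at the far end of the long ester chain gives a modest change (a number 14.4 percentage points higher from compound 2 to compound 3 (beyond the scatter)), while the much larger addition from compound 1 to compound 2 stayed within the scatter. The overall lengthening leaves the result within the scatter (a number 4.6 percentage points higher from compound 1 to compound 3 (within the scatter)), so these three compounds show no steady trend with chain length. Nothing available explains this step. On these data alone, whether an amine or a carboxylic acid at the chain end, or a longer chain, would change the number remains open.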